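The source may report more compounds than this note shows. Statements on the series, on what has been measured and on what is new or still open speak of the compounds shown alone.

Measured so far in a functional assay for activation of Alpha-1D adrenergic receptor (Homo sapiens); a lower number here means that less compound is needed, a higher number that more compound is needed for the effect:
Compound 1 `c1csc(-c2ccccc2NCC2=NCCN2)c1`: 18.2 nM
Compound 2 `Cc1ccsc1-c1ccccc1NCC1=NCCN1`: 49 nM

Among the compounds with values here, compound 2 stands highest of the two numbers in this assay; the only measured step is a 2.7-fold higher number from compound 1 to compound 2 (0.43 log units; beyond the scatter), a modest one beyond the scatter. Compound 3 `c1ccc(-c2ccccc2NCC2=NCCN2)nc1` differs from compound 2 by pyridin-2-yl in place of 3-methylthiophen-2-yl on an aromatic carbon. Within the data shown here, no measured step bears on exchanging one ring for another; the step of a 2.7-fold higher number from compound 1 to compound 2 (0.43 log units; beyond the scatter) concerns only the methyl that leaves with the ring. Compound 3 is therefore expected, with wide uncertainty, near 40 nM, between 10 nM and 160 nM. For compound 3 this estimate means a 1.2-fold lower number from compound 2 to compound 3 (0.09 log units; within the scatter), not beyond the scatter.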

Compound 3, half-maximal effective concentration: 41.7 nM
Estimate against measurement, compound 3: 1.0-fold (0.02 log units) below, and the stated range covers the measured number.
By their numbers in this assay, from the lowest: compound 1; then compounds 3 and 2 (each within the scatter of the next).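

In this assay, pyridin-2-yl in place of 3-methylthiophen-2-yl gives a 1.2-fold lower number from compound 2 to compound 3 (0.07 log units; within the scatter), so at this position a six-membered ring can stand for the methylated five-membered ring without a change beyond the scatter. Pyridin-2-yl in place of thiophen-2-yl gives a 2.3-fold higher number from compound 1 to compound 3 (0.36 log units; beyond the scatter), a modest step, which leaves compound 1 with the lowest number of the three. No supporting data explain either step. The compounds shown leave open how a plain phenyl ring or a thiazol-2-yl ring would read at this position, and whether a methyl on the pyridin-2-yl ring would raise the number as it did on the thiophene.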